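Fluoro for methoxy: from compound 2 to compound 3

A few compounds are considered here, and "the series" means these few. Any claim that something is new, unique, unknown or untested is made for them only; others in the source may bear on it.

Compound 1 `Cc1c(Br)cc(C(=O)NC2CCCCCC2)c(=O)n1Cc1ccc(F)cc1`: 5900 nM
Compound 2 `COc1ccc(-c2cc(C(=O)NC3CCCCCC3)c(OCc3ccc(F)cc3)nc2C)cc1`: > 10000 nM

In an assay on U-937 cells for inhibition of Fatty-acid amide hydrolase 1 (Homo sapiens), read by scintillation counting, with a stated time of 15 min (on this read-out higher numbers stand for weaker inhibition and lower numbers for stronger inhibition), compound 1 gives 5900 nM. For compound 2 only a limit is known, > 10000 nM, which is the limit of > 10000 nM in this assay, at which 1 of the 2 values shown sits. Compound 3 `Cc1nc(OCc2ccc(F)cc2)c(C(=O)NC2CCCCCC2)cc1-c1ccc(F)cc1` carries fluoro in place of methoxy on an aromatic carbon; cut one bond further out, 4-methoxyphenyl becomes 4-fluorophenyl. Going by the values given here, no measured pair covers this change, so no shift beyond the scatter is expected in this assay. Compound 3 is therefore expected near 12000 nM, in the range 3000 nM to 40000 nM, the expected step being a step that the limit leaves unreadable from compound 2 to compound 3.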

Compound 3, half-maximal inhibitory concentration: > 10000 nM
Compound 3 ended at the assay's limit; the forecaster's own chance of this, stated with the estimate: 60%; the middle value is on the limit's open side.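

Compound 2 and compound 3 each carry only a limit, so no step can be read for 4-methoxyphenyl to 4-fluorophenyl. Which of the two inhibits more strongly, and by how much, stays open.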